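This account rests on a few compounds, and the source may have more. Where it says the series, first, only, none or still open, it means among the compounds named here.

Of the compounds shown here, three built on one shared core have been tested in a functional assay on cells (Cancer cell lines, Homo sapiens) for inhibition; a lower number here means a stronger inhibitor of growth, a higher number a weaker inhibitor of growth. Compound 1 `COc1ccc(-c2nc3sc(Cc4ccccc4)nn3c2SC#N)cc1` gives 5600 nM. Compound 2 `O=Cc1c(-c2ccc(Br)cc2)nc2sc(Cc3ccccc3)nn12` gives 4200 nM, a number within the scatter of compound 1, so the two cannot be told apart. Compound 3 `O=Cc1c(-c2ccc(F)cc2)nc2sc(CCC3CCCCC3)nn12` gives 12300 nM, a higher number than compound 1 and beyond the scatter. Among these three numbers, compound 1 therefore sits second highest.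

Compound 4 `N#CSc1c(-c2ccccc2)nc2sc(Cc3ccccc3)nn12` has not yet been measured. Its difference from compound 1 is hydrogen in place of methoxy on an aromatic carbon. For the measured compounds named here, no pair of measured compounds here differs in only one place, so no measured step shows how a change of this kind plays out in this assay. With nothing to build on beyond the three numbers, the change is expected to bring no step beyond the scatter, estimated as a 1.1-fold higher number from compound 1 to compound 4 (0.03 log units; within the scatter). Compound 4 is accordingly expected to give 6000 nM, with a range from 2500 nM to 15000 nM.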

Compound 4, concentration for 50% growth inhibition: 9800 nM
For compound 4 the middle estimate is 1.6-fold (0.21 log units) below the measured one; low and high end bracket the measured number.
By their numbers in this assay, from the lowest: compounds 2, 1, 4 and 3 (each within the scatter of the next, the first and the last beyond it).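

Going from 4-methoxyphenyl to phenyl gives a 1.8-fold higher number from compound 1 to compound 4 (0.24 log units; within the scatter) in this assay, the first comparison here between two compounds that differ in one place only. The step stays within the scatter, so compound 1 and compound 4 cannot be told apart, and the methoxy group on this ring is not required for the growth inhibition seen with compound 1. Nothing measured here accounts for this result.

Only hydrogen and methoxy can be compared directly at this position, so a single pair says little about how other groups would behave there. Going by these compounds, whether an amine, a carboxylic acid or a longer ether chain in the same place would leave the number within the scatter or shift it clearly remains open.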